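Aryl variation on the shared core: step to compound 4

A few compounds are considered here, and "the series" means these few. Any claim that something is new, unique, unknown or untested is made for them only; others in the source may bear on it.

Measured so far:
Compound 1 `COc1cc(NC(=O)Nc2cc(Nc3ccc(C(C)(C)C)cc3)ncn2)cc(OC)c1`: 38.7% in a functional assay on NCI-H1581 cells (Homo sapiens) for inhibition, read by MTT assay, with a stated time of 48 h, tested at 10 uM; a lower number here means less inhibition, a higher number more inhibition at the concentration tested (going by the name of the read-out)
Compound 2 `COc1cc(NC(=O)Nc2cc(Nc3ccc(C)c(C)c3)ncn2)cc(OC)c1`: 20.1% in this assay
Compound 3 `COc1cc(NC(=O)Nc2cc(Nc3cc(F)ccc3OC)ncn2)cc(OC)c1`: 42.1% in this assay

Compound 3 holds the highest of the three numbers. The step from the nearest of the other numbers reads a number 3.4 percentage points higher from compound 1 to compound 3 (within the scatter), which lies within the scatter, so those two cannot be ordered. The step from the furthest of the other numbers reads a number 22 percentage points higher from compound 2 to compound 3 (beyond the scatter), beyond the scatter, and the remaining pair reads a number 18.6 percentage points lower from compound 1 to compound 2 (beyond the scatter).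

Compound 4 `COc1cc(NC(=O)Nc2cc(Nc3ccc(OC)c(I)c3)ncn2)cc(OC)c1` differs from compound 3 only at the aryl group on the nitrogen: 3-iodo-4-methoxyphenyl in place of 5-fluoro-2-methoxyphenyl on a nitrogen on an aromatic ring

Among the measured compounds shown here, no measured step covers this exchange. The three aryl variants shown span a moderate window in this assay; two of the three lie near the top of it, one well below. With no closer guide, the expectation for compound 4 is a step of a number 6.1 percentage points lower from compound 3 to compound 4 (within the scatter), inside the scatter, with a wide range. Compound 4 is estimated at 36%, between 16% and 56%.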

Compound 4, a percentage reported as inhibition, at one concentration (the size of the read-out at that concentration, not a potency): 43%
Beside the measured number, compound 4's estimate is 7 percentage points below it; the measured number falls inside the stated range.
By their numbers in this assay, from the lowest: compound 2; then compounds 1, 3 and 4 (each within the scatter of the next).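

In this assay, 3-iodo-4-methoxyphenyl in place of 5-fluoro-2-methoxyphenyl on this nitrogen gives no readable change (a number 0.9 percentage points higher from compound 3 to compound 4 (within the scatter)), so exchanging the fluorine for an iodine and moving the methoxy group leaves the read-out unresolved here. The same group also cannot be separated from 4-(tert-butyl)phenyl (a number 4.3 percentage points higher from compound 1 to compound 4 (within the scatter)) but stands clear of 3,4-dimethylphenyl (a number 22.9 percentage points higher from compound 2 to compound 4 (beyond the scatter)), which leaves compound 2 as the only one of the four aryl variants set apart from the others. Nothing available accounts for these results.

Going by these compounds, the separate contributions of the iodine and the methoxy group in compound 4 remain open. So does the read-out with a morpholine, an amine or a carboxylic acid on the aryl ring at this position.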